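A few compounds are considered here, and "the series" means these few. Any claim that something is new, unique, unknown or untested is made for them only; others in the source may bear on it.

Three compounds share one core and differ in the group on the amide-type nitrogen. In a functional assay on HL-60 cells (Homo sapiens) for antiproliferative activity, read by sulforhodamine B assay, with a stated time of 72 h (on this read-out lower numbers stand for stronger inhibition and higher numbers for weaker inhibition), compound 1 `Cc1cccc(NC(=S)N/N=C/c2ccc3ccccc3n2)c1` gives > 100000 nM, which is a limit of the assay and not a number. Compound 3 `Cc1ccccc1NC(=S)N/N=C/c1ccc2ccccc2n1` gives 73200 nM, and compound 2 `COc1cccc(NC(=S)N/N=C/c2ccc3ccccc3n2)c1` gives 71200 nM. These two stand level, since the measured change is a 1.0-fold higher number from compound 2 to compound 3 (0.01 log units; within the scatter).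

Compound 4 `COc1ccc(NC(=S)N/N=C/c2ccc3ccccc3n2)cc1` has 4-methoxyphenyl in place of 2-methylphenyl on an amide-type nitrogen. Among the measured compounds shown here, three measured steps bear on this swap. Two start from the limit, so they give only floors: an at least 1.4-fold lower number from compound 1 to compound 2 (0.14 log units; that floor lies within the scatter) and an at least 1.3-fold lower number from compound 1 to compound 3 (0.13 log units; that floor lies within the scatter). The third is the step between compound 2 and compound 3 given above, and it is the only one with numbers at both ends. None of the three shows a change beyond the scatter, so no clear shift is expected in this assay. The expected change is a 1.1-fold lower number from compound 3 to compound 4 (0.05 log units; within the scatter), which means no step beyond the scatter. The estimate for compound 4 is 65000 nM, with an expected range from 25000 nM to 100000 nM.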

Compound 4, half-maximal inhibitory concentration: 43800 nM
Estimate against measurement, compound 4: 1.5-fold (0.17 log units) above; low and high end bracket the measured number.
By their numbers in this assay, from the lowest: compounds 4, 2 and 3 (each within the scatter of the next). At a limit, above all of these: compound 1.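

Among the compounds shown here, the only step here beyond the scatter in this assay is an at least 2.2-fold lower number from compound 1 to compound 4 (0.35 log units; beyond the scatter), so 4-methoxyphenyl is the first group on the amide-type nitrogen to show a clear step, though only against compound 1. Against the two partners with numbers at both ends, the swap stays within the scatter: a 1.7-fold lower number from compound 3 to compound 4 (0.22 log units; within the scatter) and a 1.6-fold lower number from compound 2 to compound 4 (0.21 log units; within the scatter), so these results set compounds 2, 3 and 4 in no order. Compound 1 gives > 100000 nM, a limit of the assay and not a number, which makes its step a floor rather than a measured size: the limit of > 100000 nM in this assay, at which 1 of the 4 values shown sits.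

The compounds shown leave open whether 2-methoxyphenyl or 4-methylphenyl would match compound 4, which would help separate the group from its place on the phenyl. They also leave open what a phenyl carrying an amine or a carboxylic acid would give.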